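Moving the furan attachment at the assay limit

The compounds below may be only part of what the source reports. "The series", "measured", "known", "first", "only" and "open" are said of these compounds alone.

Compound 1 `O=c1[nH]cnc2c1c(-c1cc3ccccc3o1)cn2[C@@H]1O[C@H](CO)[C@@H](O)[C@H]1O` gives > 20000 nM as a limit
Compound 2 `Nc1nc(N)c2c(-c3ccco3)cn([C@@H]3O[C@H](CO)[C@@H](O)[C@H]3O)c2n1` gives > 20000 nM as a limit
Compound 3 `COc1nc(N)nc2c1c(-c1ccco1)cn2[C@@H]1O[C@H](CO)[C@@H](O)[C@H]1O` gives > 20000 nM as a limit

All three compounds were tested in a functional assay on CEM-DNR-bulk cells (Homo sapiens), read by MTT assay, with a stated time of 72 h (on this read-out higher numbers stand for weaker inhibition and lower numbers for stronger inhibition), and each result is a limit of the assay, not a number. Compound 3 therefore has no exact place on the scale. This is the limit of > 20000 nM in this assay, at which 3 of the 3 values shown sit, and so no order among the three can be read.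

The next compound, compound 4 `COc1nc(N)nc2c1c(-c1ccoc1)cn2[C@@H]1O[C@H](CO)[C@@H](O)[C@H]1O` differs from compound 3 only at the furan: furan-3-yl in place of furan-2-yl on an aromatic carbon and the two have the same atoms, joined differently. For the measured compounds named here, the only measured step is a step that the two limits leave unreadable from compound 2 to compound 3 and it lies at another place, so it offers no size to carry over. Going by the values given here, no step at the furan attachment has been measured. No direction can therefore be given, and no step beyond the scatter is expected in this assay from this swap.

The expected step is a number no higher from compound 3 to compound 4 (the limit leaves the size open) as an estimate. This expectation rests on compound 3 at > 20000 nM as a limit, and another limit is the likeliest report. The estimate for compound 4 is 20000 nM with an expected range from 7000 nM to 40000 nM in this measurement.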

Compound 4, half-maximal inhibitory concentration: > 20000 nM
Compound 4: no number, only a limit; the forecaster's own chance of this, stated with the estimate: 85%; the middle value sits exactly at the limit.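

No step can be read between compound 3 and compound 4, so the swap from furan-2-yl to furan-3-yl has no measurable size, because both results are limits rather than numbers: the limit of > 20000 nM in this assay, at which 4 of the 4 values shown sit.

The compounds shown leave open whether the furan attachment matters at all, and what exact value any of the four compounds has.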